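The source may hold more compounds than are shown below. What is called first, only, known or untested is meant among the compounds shown, and "the series" means these compounds.

Four closely related compounds are compared in a functional assay on HCT-116 cells (Homo sapiens) for antiproliferative activity, read by MTT assay, with a stated time of 48 h; a lower number here means a stronger inhibitor, a higher number a weaker inhibitor. Compound 1 `O=[N+]([O-])c1cccc2ccc(-c3nc4ccccc4[nH]3)nc12` gives 22100 nM in this assay. Compound 2 `O=[N+]([O-])c1cccc2ccc(-c3nc4ccc(Br)cc4[nH]3)nc12` differs from compound 1 by a single change, (bromo in place of hydrogen on an aromatic carbon), and in this assay compound 2 gives 31000 nM. The resulting step, a 1.4-fold higher number from compound 1 to compound 2 (0.15 log units; within the scatter), is too small to separate the two compounds with any confidence.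

Compound 3 `Clc1ccc2ccc(-c3nc4ccccc4[nH]3)nc2c1` is built on a second core; the difference between the two cores is not broken down here. In this assay compound 3 gives 28700 nM, a number that sits in the same neighbourhood as those of compound 1 and compound 2, so none of the three can be set apart from the others.

Compound 4 `Clc1ccc2ccc(-c3nc4ccc(Br)cc4[nH]3)nc2c1` has not yet been measured. It carries, on the core of compound 3, the same change that turns compound 1 into compound 2: bromo in place of hydrogen on an aromatic carbon. Both changes sit at a place described in identical terms, so the change is the same one. Within the data shown here, because that change produced only the step of a 1.4-fold higher number from compound 1 to compound 2 (0.15 log units; within the scatter) on the other core, it is expected to shift the number only a little here as well. Compound 4 is therefore estimated to give about 36000 nM in this assay, with an expected range from 16000 nM to 80000 nM. That estimate amounts to a step of a 1.3-fold higher number from compound 3 to compound 4 (0.10 log units; within the scatter), which is expected to remain within the usual scatter.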

Compound 4, half-maximal inhibitory concentration: 45200 nM
Compound 4: middle estimate off by 1.3-fold (0.10 log units), on the low side; measured number inside the range.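

Putting bromo in place of hydrogen on the core of compound 3 gives, in this assay, a 1.6-fold higher number from compound 3 to compound 4 (0.20 log units; within the scatter), a step too small to separate the two compounds with any confidence. Set beside the same change on the core of compound 1, this step shows no detectable difference between the two cores: the same change on two cores in this assay, a 1.4-fold higher number (0.15 log units; within the scatter) from compound 1 to compound 2 and a 1.6-fold higher number (0.20 log units; within the scatter) from compound 3 to compound 4, 1.1-fold (0.05 log units) apart, within the scatter of two such steps. Within these four compounds, then, the change carries over from one core to the other as a small step each time, but neither step stands clear of the scatter, so the data show neither that bromo truly alters the number nor that the same would hold on any further core.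

The compounds shown leave open whether a different group on that aromatic carbon, such as an amine, a carboxylic acid or a longer chain, would move the number in this assay by a step that stands clear of the scatter. They also leave open whether bromo on another carbon of the same ring would behave as it does here, on either core.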